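Removing the Chloro Group from Compound 1

This account rests on a few compounds, and the source may have more. Where it says the series, first, only, none or still open, it means among the compounds named here.

Compound 1, `Cc1nnc(SCc2coc3ccc(Cl)cc3c2=O)o1`: 3200 nM
Compound 2, `Cc1nnc(SCc2coc3ccc(Cl)cc3c2=O)s1`: 9700 nM
Compound 3, `Cc1cc(C)nc(SCc2coc3ccccc3c2=O)n1`: > 25000 nM (a limit, not a number)

In a functional assay on HeLa cells (Homo sapiens) for cytotoxicity, read by MTT assay, with a stated time of 72 h (on this read-out higher numbers stand for weaker inhibition and lower numbers for stronger inhibition), compound 1 gives 3200 nM, the lowest of the two numbers. Its nearest neighbour is compound 2, reached through a 3.0-fold higher number from compound 1 to compound 2 (0.48 log units; beyond the scatter). Compound 3 reaches only (the limit of > 25000 nM in this assay, at which 1 of the 3 values shown sits).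

Compound 4, `Cc1nnc(SCc2coc3ccccc3c2=O)o1`, differs from compound 1 in hydrogen in place of chloro on an aromatic carbon. No measured step touches this chloro group; the single step shown, a 3.0-fold higher number from compound 1 to compound 2 (0.48 log units; beyond the scatter), alters the heterocycle on the sulfur and gives no direct guide here. The change is expected to amount to a 2.0-fold higher number from compound 1 to compound 4 (0.31 log units; beyond the scatter), most likely towards weaker inhibition, with wide uncertainty. Compound 4 is therefore estimated at 6500 nM, in a range from 2000 nM to 25000 nM.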

Compound 4, half-maximal inhibitory concentration: 1400 nM
Compound 4: middle estimate off by 4.6-fold (0.67 log units), on the high side, outside the stated range (below it).
By their numbers in this assay, from the lowest: compound 4; then compound 1; then compound 2. At a limit, above all of these: compound 3.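

At this aromatic carbon, the chloro group is not required for the activity seen in this assay, since hydrogen in its place gives a 2.3-fold lower number from compound 1 to compound 4 (0.36 log units; beyond the scatter). The step is modest but beyond the scatter, and it runs towards stronger inhibition, so here the chloro group costs activity rather than adding to it. Nothing measured here offers a reason for this change.

Going by these compounds, whether fluoro, methyl or methoxy on the same carbon would also give stronger inhibition than chloro stays open. So does whether hydrogen in place of chloro would move compound 2 the same way.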